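The source may hold more compounds than are shown below. What is called first, only, known or untested is meant among the compounds shown, and "the series" means these compounds.

Compound 1 `Cc1nc(C)c([C@H](OC(C)(C)C)C(=O)O)c(N2CCC(C)(C)CC2)c1-c1ccc2c(c1)CC[C@@H](Cc1ccc(F)cc1)O2`, compound 2 `Cc1nc(C)c([C@H](OC(C)(C)C)C(=O)O)c(N2CCC(C)(C)CC2)c1-c1cnn(CCCc2ccc(F)cc2)c1` and compound 3 `Cc1cccc(F)c1CN1CCc2cc(-c3c(C)nc(C)c([C@H](OC(C)(C)C)C(=O)O)c3N3CCC(C)(C)CC3)ccc2C1` share one core and were all tested in a toxicity assay on MT2 cells (Homo sapiens) for cytotoxicity; a higher number here means that more compound is tolerated, a lower number that less compound is tolerated. Compound 1 reaches only a limit of the assay, >= 22000 nM. Compound 2 likewise gives only a limit, >= 22000 nM. Compound 3 also sits at a limit, >= 24000 nM. Thus the limit of >= 22000 nM in this assay, at which 2 of the 3 values shown sit, and the limit of >= 24000 nM in this assay, at which 1 of the 3 values shown sits, cover all three values, and compound 3 stands among them with no number of its own. Compound 4 `Cc1nc(C)c([C@H](OC(C)(C)C)C(=O)O)c(N2CCC(C)(C)CC2)c1-c1ccc2c(c1)CCN(c1nc3cnccc3s1)C2`, not yet measured, differs from compound 3 by a group of 9 heavy atoms (6 carbon, 2 nitrogen, 1 sulfur; one five-membered aromatic ring with 2 hetero atoms, one six-membered aromatic ring with 1 hetero atom) in place of a group of 9 heavy atoms (8 carbon, 1 fluorine; one six-membered aromatic ring of carbon only), on an amine nitrogen in a ring. Among the compounds with values here, no measured step exists for a change of this kind; the expectation for compound 4 in this assay is no step beyond the scatter, a number no higher from compound 3 to compound 4 (the limit leaves the size open), most likely again a limit. Compound 4 is expected at 24000 nM, between 15000 nM and 60000 nM.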

Compound 4, half-maximal cytotoxic concentration: >= 17000 nM
Compound 4: no number, only a limit; the forecaster's own chance of this, stated with the estimate: 85%; the middle value does not contradict the limit.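

Within the data shown here, compound 3 and compound 4 both give only limits in this assay, so no step between them can be read. The compounds shown leave open at what concentration any of them turns cytotoxic, and whether exchanging the 2-fluoro-6-methylbenzyl group changes this.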